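Chloro for Methoxy on the Aromatic Ring of Compound 3

A few compounds are considered here, and "the series" means these few. Any claim that something is new, unique, unknown or untested is made for them only; others in the source may bear on it.

Compound 1, `COc1cc(CCc2cccc(Cl)c2Cl)cc(OC)c1O`, gives 3990 nM in a functional assay on A549 cells (Homo sapiens) for antiproliferative activity, read by MTT assay, with a stated time of 72 h; on this read-out higher numbers stand for weaker inhibition and lower numbers for stronger inhibition.
Compound 2, `COc1cc(CCc2ccccc2F)cc(OC)c1O`, reaches in this assay only the assay limit, > 25000 nM.
Compound 3, `COc1ccccc1CCc1cc(OC)c(O)c(OC)c1`, gives 1740 nM in this assay.

Compound 3 holds the lowest of the two numbers shown; the nearest, compound 1 at 3990 nM, lies beyond the usual scatter above it. Compound 4, `COc1cc(CCc2ccccc2Cl)cc(OC)c1O`, differs from compound 3 by chloro in place of methoxy on an aromatic carbon. Among the measured compounds shown here, one measured step bears on this position: an at least 14-fold lower number from compound 2 to compound 3 (1.15 log units; beyond the scatter). That step starts from a value that is only (the limit of > 25000 nM in this assay, at which 1 of the 3 values shown sits). Compound 1, which also carries chloro, gives 3990 nM, a higher number than compound 3. A moderate rise is therefore expected, a 2.9-fold higher number from compound 3 to compound 4 (0.46 log units; beyond the scatter). Compound 4 is estimated to give 5000 nM, within 1500 nM to 20000 nM.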

Compound 4, half-maximal inhibitory concentration: 2130 nM
The estimate for compound 4 lay 2.3-fold (0.37 log units) above the measured number, within the range that was stated.
By their numbers in this assay, from the lowest: compounds 3, 4 and 1 (each within the scatter of the next, the first and the last beyond it). At a limit, above all of these: compound 2.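

In this assay, chloro and methoxy on this aromatic carbon, ortho to a large group, cannot be told apart: a 1.2-fold higher number from compound 3 to compound 4 (0.09 log units; within the scatter). Hydrogen in place of the further chloro of compound 1 also stays within the scatter: a 1.9-fold lower number from compound 1 to compound 4 (0.27 log units; within the scatter). Only fluoro stands apart, with an at least 11-fold lower number from compound 2 to compound 4 (1.06 log units; beyond the scatter), a step whose size is only a lower bound, set by a limit: the limit of > 25000 nM in this assay, at which 1 of the 4 values shown sits.

The compounds shown leave open how an amine, a nitrile or a carboxylic acid would read at this place. They also leave open how far compound 2 really lies from compound 4.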